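One Methyl Fewer on the Sulfonate Ester Aryl Group

The compounds below may be only part of what the source reports. "The series", "measured", "known", "first", "only" and "open" are said of these compounds alone.

Measured compounds, each in a functional assay on HT-29 cells (Homo sapiens) for antiproliferative activity, read by sulforhodamine B assay, with a stated time of 48 h; on this read-out higher numbers stand for weaker inhibition and lower numbers for stronger inhibition:
- compound 1 `CCCN1CCN(c2ccc(S(=O)(=O)Oc3ccccc3C)cc2)C1=O` gives > 100000 nM, which is a limit of the assay and not a number.
- compound 2 `CCCN1CCN(c2ccc(S(=O)(=O)Oc3ccccc3CC)cc2)C1=O` gives > 100000 nM, again a limit of the assay and not a number.
- compound 3 `CCCN1CCN(c2ccc(S(=O)(=O)Oc3ccc(C)cc3C)cc2)C1=O` gives 26000 nM.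

Compound 3 is thus the only one of the three with a measured number; the other two sit at the limit (the limit of > 100000 nM in this assay, at which 2 of the 3 values shown sit). Going by the values given here, the single step that moved beyond the scatter was an at least 3.8-fold lower number from compound 1 to compound 3 (0.58 log units; beyond the scatter), brought about by a methyl in place of hydrogen on an aromatic carbon, and likewise an at least 3.8-fold lower number from compound 2 to compound 3 (0.58 log units; beyond the scatter). The step from compound 1 to compound 2 is not readable between the two limits.

Compound 4 `CCCN1CCN(c2ccc(S(=O)(=O)Oc3cccc(C)c3)cc2)C1=O` takes the opposite direction: 3-methylphenyl in place of 2,4-dimethylphenyl on an oxygen. One methyl on an aromatic carbon is removed and the remaining one shifted, so the aryl group again carries a single methyl, as it did in compound 1, whose value sits at the limit. Compound 4 is therefore expected to be weaker, with a 3.8-fold higher number from compound 3 to compound 4 (0.59 log units; beyond the scatter) in this assay , and may well return only a limit; the estimate is 100000 nM, between 30000 nM and 300000 nM.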

Compound 4, half-maximal inhibitory concentration: 65000 nM
For compound 4 the middle estimate is 1.5-fold (0.19 log units) above the measured one; low and high end bracket the measured number.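

Replacing 2,4-dimethylphenyl with 3-methylphenyl on the oxygen gives a 2.5-fold higher number from compound 3 to compound 4 (0.40 log units; beyond the scatter) in this assay, yet compound 4 still returns a number, so among the compounds shown a second methyl is not needed for a measurable value. Against the two compounds that carry a limit, only floors can be read, and neither separates them firmly from compound 4: an at least 1.5-fold lower number from compound 1 to compound 4 (0.18 log units; that floor lies within the scatter) and an at least 1.5-fold lower number from compound 2 to compound 4 (0.18 log units; that floor lies within the scatter). How far those two really lie from compound 4 therefore stays unknown: the limit of > 100000 nM in this assay, at which 2 of the 4 values shown sit.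

The compounds shown leave open whether this activity depends on a methyl at all, or would also appear with a methoxy group, a chlorine or an amine on the aryl group. The removal of one methyl and the shift of the other also remain unseparated in this single step.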